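This account rests on a few compounds, and the source may have more. Where it says the series, first, only, none or still open, it means among the compounds named here.

Working notes on the series. Compound 1 `CN(C)c1ccc(/C=N\NC(=S)NC2CCCCC2)cc1` gives 125000 nM in a functional assay on MDA-MB-231 cells (Homo sapiens) for inhibition, read by WST assay, with a stated time of 48 h (on this read-out higher numbers stand for weaker inhibition and lower numbers for stronger inhibition), the highest of the two numbers recorded so far. Within the data shown here, compound 2 `Oc1cccc(/C=N\NC(=S)NC2CCCCC2)c1` gives 24500 nM in this assay; the gap between the two is beyond the scatter, so compound 2 inhibits more strongly than compound 1, but the two structures differ in more than one place and no single-point step joins them. Compound 3 `CCOc1ccc(/C=N\NC(=S)NC2CCCCC2)cc1` has not yet been measured in this assay. It differs from compound 1 by ethoxy in place of dimethylamino on an aromatic carbon. Among the measured compounds shown here, no measured pair shows this exchange, so any expectation for compound 3 rests on little more than the spread of the two numbers in hand. A modest move toward stronger inhibition, only a little beyond the scatter, is expected: a 2.1-fold lower number from compound 1 to compound 3 (0.32 log units; beyond the scatter). Compound 3 is accordingly estimated at 60000 nM in this assay, within a range of 15000 nM to 200000 nM.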

Compound 3, half-maximal inhibitory concentration: 68200 nM
Estimate against measurement, compound 3: 1.1-fold (0.06 log units) below, within the range that was stated.
By their numbers in this assay, from the lowest: compound 2; then compounds 3 and 1 (each within the scatter of the next).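

Among these compounds, the step of a 1.8-fold lower number from compound 1 to compound 3 (0.26 log units; within the scatter) in this assay is the first single-point comparison, and it shows that ethoxy can take the place of dimethylamino on this aromatic carbon, para to a large group, without a difference that stands clear of the scatter. The two groups match in what is counted, each with 3 heavy atoms, no ring, no hydrogen-bond donors and 1 hydrogen-bond acceptor, and they differ in oxygen against nitrogen. Nothing available bears on the reason for this result.

Still open, as far as these compounds go, is whether a primary amine, a carboxylic acid or a longer alkoxy chain such as butoxy at this place would depart from the level of compound 1 and compound 3. This one exchange also says nothing about changes elsewhere on the shared core.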